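A few compounds are considered here, and "the series" means these few. Any claim that something is new, unique, unknown or untested is made for them only; others in the source may bear on it.

Compound 1, `O=c1n(Cc2cc3cc(Cl)ccc3n2CCCCO)c2cnccc2n1C1CC1`: in an ADME assay on HeLa cells (Homo sapiens) for cytotoxicity, read by ATP content, with a stated time of 3 days (on this read-out lower numbers stand for higher toxicity in this test and higher numbers for lower toxicity in this test), compound 1 gives > 50000 nM, which is a limit of the assay.
Compound 2, `O=c1n(Cc2cc3cc(Cl)ccc3n2CCCC(F)(F)F)c2cnccc2n1C1CC1`: in this assay compound 2 gives > 50000 nM, again a limit of the assay.
Compound 3, `N#CCCCn1c(Cn2c(=O)n(-c3ncco3)c3ccncc32)cc2cc(Cl)ccc21`: in this assay compound 3 gives > 50000 nM, once more a limit of the assay.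

Compound 3 thus stands at the limit, exactly where every measured value sits, as the limit of > 50000 nM in this assay, at which 3 of the 3 values shown sit, records. The unmeasured compound 4, `N#CCCCn1c(Cn2c(=O)n(-c3ccncn3)c3ccncc32)cc2cc(Cl)ccc21`, differs from compound 3 in one place: pyrimidin-4-yl in place of 1,3-oxazol-2-yl on an aromatic nitrogen. Only one measured step exists among these compounds, a step that the two limits leave unreadable from compound 1 to compound 2, and it alters a saturated chain rather than the group on the aromatic nitrogen, and with both of its ends at the limit its size cannot be read anyway. For the measured compounds named here, no measured step therefore bears directly on the change from compound 3 to compound 4. Because the limit of > 50000 nM in this assay, at which 3 of the 3 values shown sit, shows every measured compound at the limit, the expectation is that compound 4 will likewise show no measurable toxicity in this assay. The step from compound 3 to compound 4 is expected to be a number no higher from compound 3 to compound 4 (the limit leaves the size open), nothing beyond the scatter. Compound 4 is estimated at 50000 nM, with a range from 20000 nM to 100000 nM.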

Compound 4, half-maximal cytotoxic concentration: > 50000 nM
Compound 4 ended at the assay's limit; the forecaster's own chance of this, stated with the estimate: 85%; the middle value lies on the limit itself.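

In this assay compound 3 and compound 4 both end at a limit of the assay, and no size can be read for the change from 1,3-oxazol-2-yl to pyrimidin-4-yl. The compounds shown leave open whether any of them differs in toxicity from the others, since all share one limit: the limit of > 50000 nM in this assay, at which 4 of the 4 values shown sit.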